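A Fluoro-to-Chloro Change and What It Predicts for Compound 4

This account rests on a few compounds, and the source may have more. Where it says the series, first, only, none or still open, it means among the compounds named here.

Compound 1 `CCN(CC)c1nc(Nc2cccc(F)c2)nc(OC(C(F)(F)F)C(F)(F)F)n1` is the starting point of this small set. In an assay on cells for activation of Cystic fibrosis transmembrane conductance regulator (Homo sapiens), read by fluorescence, with stated times of 10 min and 12 s (on this read-out lower numbers stand for an effect already at smaller amounts and higher numbers for an effect only at larger amounts of compound), compound 1 gives 140 nM. Compound 2 `CCN(CC)c1nc(Nc2cccc(Cl)c2)nc(OC(C(F)(F)F)C(F)(F)F)n1` carries chloro in place of fluoro on an aromatic carbon; in this assay compound 2 gives 2800 nM, and the step is a 20-fold higher number from compound 1 to compound 2 (1.30 log units; beyond the scatter). Compound 3 `CCN(CC)c1nc(Nc2cccc(F)c2)nc(OCC(F)(F)C(F)F)n1` differs from compound 1 by 2,2,3,3-tetrafluoropropyl in place of 2,2,2-trifluoro-1-(trifluoromethyl)ethyl on an oxygen on an aromatic ring; in this assay compound 3 gives 1600 nM, which is an 11-fold higher number from compound 1 to compound 3 (1.06 log units; beyond the scatter). Compound 2 and compound 3 lie within the usual scatter of one another.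

Compound 4 `CCN(CC)c1nc(Nc2cccc(Cl)c2)nc(OCC(F)(F)C(F)F)n1` has not been measured. It differs from compound 3 by chloro in place of fluoro on an aromatic carbon, the same change that turns compound 1 into compound 2, and the place is described in the same words for both pairs. Because that change gave a 20-fold higher number from compound 1 to compound 2 (1.30 log units; beyond the scatter), compound 4 is expected to give a higher number than compound 3, although the core of compound 3 differs from that of compound 1, so the size of the step need not repeat exactly. The expected step is a 13-fold higher number from compound 3 to compound 4 (1.10 log units; beyond the scatter). Compound 4 is estimated at 20000 nM, with a likely range from 5000 nM to 60000 nM.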

Compound 4, half-maximal effective concentration: 5400 nM
The estimate for compound 4 lay 3.7-fold (0.57 log units) above the measured number; low and high end bracket the measured number.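

In this assay, chloro in place of fluoro again raises the number on the core of compound 3, with a 3.4-fold higher number from compound 3 to compound 4 (0.53 log units; beyond the scatter), so the direction carries over but the size does not: the same change on two cores in this assay, a 20-fold higher number (1.30 log units; beyond the scatter) from compound 1 to compound 2 and a 3.4-fold higher number (0.53 log units; beyond the scatter) from compound 3 to compound 4, 5.9-fold (0.77 log units) apart, beyond the scatter of two such steps

The 2,2,3,3-tetrafluoropropyl change depends on its partner in the same way, since with chloro on the ring it gives only a 1.9-fold higher number from compound 2 to compound 4 (0.29 log units; within the scatter), a step that cannot be told from repeat-measurement noise: the same change on two cores in this assay, an 11-fold higher number (1.06 log units; beyond the scatter) from compound 1 to compound 3 and a 1.9-fold higher number (0.29 log units; within the scatter) from compound 2 to compound 4, 5.9-fold (0.77 log units) apart, beyond the scatter of two such steps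

Together these results show that, in these four compounds, the effects of the two changes do not simply add, so a step measured on one core is a guide to direction at best and not a reliable figure for size; they do not show why the steps differ, or whether the same holds for any other pair of cores.

The compounds shown leave open how a bromo or a methyl group would behave at the same place on the ring. They also leave open whether a longer chain on the oxygen would shrink or widen the chloro-for-fluoro step.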